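The source may hold more compounds than are shown below. What is called first, only, known or untested is meant among the compounds shown, and "the series" means these compounds.

Compound 1 `C=C(Br)C(=O)Nc1ccc(/C=C/C(=O)c2ccc(F)cc2)cc1`: 660 nM
Compound 2 `C=C(Br)C(=O)Nc1ccc(C(=O)/C=C/c2ccccc2)cc1`: 500 nM

In a functional assay on MOLT-4 cells (Homo sapiens) for antiproliferative activity, with a stated time of 48 h (a higher number here means a weaker inhibitor, a lower number a stronger inhibitor), compound 2 gives 500 nM and compound 1 gives 660 nM, two values that lie within the scatter of each other. Compound 3 `C=C(Br)C(=O)Nc1ccc(C(=O)/C=C/c2cccc(OC)c2)cc1` departs from compound 2 by methoxy in place of hydrogen on an aromatic carbon, so that phenyl becomes 3-methoxyphenyl. Within the data shown here, no measured pair shows what this change does, so no step beyond the scatter is expected, in either direction. The expected step, a 1.1-fold lower number from compound 2 to compound 3 (0.05 log units; within the scatter), is correspondingly small. For compound 3 the estimated value is 450 nM, with an expected range of 180 nM to 1100 nM.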

Compound 3, half-maximal inhibitory concentration: 1100 nM
For compound 3 the middle estimate is 2.4-fold (0.39 log units) below the measured one; low and high end bracket the measured number.
By their numbers in this assay, from the lowest: compounds 2, 1 and 3 (each within the scatter of the next, the first and the last beyond it).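

In this assay methoxy in place of hydrogen, on an aromatic carbon meta to a large group, brings a 2.2-fold higher number from compound 2 to compound 3 (0.34 log units; beyond the scatter) as a modest weakening. Among these compounds, this is the first single change here with a readable effect, and it shows that this position responds to substitution, though compound 3 keeps a measurable effect on the cells. Nothing available accounts for the step. As far as these compounds go, whether an amine or a carboxylic acid at this same place would weaken compound 2 likewise stays open, as does the effect of methoxy elsewhere on the ring.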